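Swapping fluorophenyl for pyridyl on a phenol core

The source may report more compounds than this note shows. Statements on the series, on what has been measured and on what is new or still open speak of the compounds shown alone.

Compound 1, `C=C1C(=O)[C@]23C[C@@]1(O)CC[C@H]2c1ccc(OS(=O)(=O)c2ccc(C)cc2)c(C)c1[C@@H]3Cn1cc(-c2ccccn2)nn1`, gives 2310 nM in a functional assay on A549 cells (Homo sapiens) for cytotoxicity, read by MTT assay, with a stated time of 4 days; on this read-out lower numbers stand for stronger inhibition and higher numbers for weaker inhibition.
Compound 2, `C=C1C(=O)[C@]23C[C@@]1(O)CC[C@H]2c1ccc(OS(=O)(=O)c2ccc(C)cc2)c(C)c1[C@@H]3Cn1cc(-c2ccc(Br)cc2)nn1`, gives 1630 nM in this assay.
Compound 3, `Cc1c(O)ccc2c1[C@H](Cn1cc(-c3ccc(F)cc3)nn1)[C@@]13CC(=O)[C@@](C)(CC[C@@H]21)C3`, gives > 20000 nM in this assay, which is a limit of the assay and not a number.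

Compounds 1 and 2 share one core and compound 3 has another; each core stands beside its compound. Compound 3 therefore sits at the ceiling of what this assay reports, and it is the single one of the three values that rests there (the limit of > 20000 nM in this assay, at which 1 of the 3 values shown sits). Among the compounds with values here, no step between compound 3 and either of the other two is counted, since their cores differ in more than one place.

Compound 4, `Cc1c(O)ccc2c1[C@H](Cn1cc(-c3ccccn3)nn1)[C@@]13CC(=O)[C@@](C)(CC[C@@H]21)C3`, keeps the core of compound 3 and differs from it only in one group: pyridin-2-yl in place of 4-fluorophenyl on an aromatic carbon. Within the data shown here, the one measured step that speaks to this kind of swap lies in the other core, a 1.4-fold lower number from compound 1 to compound 2 (0.15 log units; within the scatter), where a halogen-bearing phenyl and pyridin-2-yl gave numbers within the scatter of each other. On that evidence, the step from compound 3 to compound 4 in this assay is expected to stay within the scatter, at a step that the limit leaves unreadable from compound 3 to compound 4. Compound 4 is thus expected to give 30000 nM, within a range from 8000 nM to 100000 nM, and most likely the assay will again report only a limit.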

Compound 4, half-maximal inhibitory concentration: > 20000 nM
Compound 4: a limit, no number; the forecaster's own chance of this, stated with the estimate: 70%; the middle value lies beyond the limit too.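

No step from compound 3 to compound 4 can be read, because each of them gives only a limit of the assay and not a number: the limit of > 20000 nM in this assay, at which 2 of the 4 values shown sit.

The compounds shown leave open how pyridin-2-yl and 4-fluorophenyl compare on the core of compound 3, and whether any group there would give a readable number.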